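Ester chain length and calcium channel binding in a dihydropyridine series

The compounds below may be only part of what the source reports. "The series", "measured", "known", "first", "only" and "open" are said of these compounds alone.

Measured compounds:
compound 1, `CCCOC(=O)C1=C(C)NC(C)=C(C(=O)OCCC)C1c1csc(-c2ccc(Cl)cc2)n1`, gives 4800 nM in an assay on isolated protein for antagonist activity at Voltage-dependent L-type calcium channel subunit alpha-1C (Cavia porcellus), with a stated time of 15 min; on this read-out lower numbers stand for stronger inhibition and higher numbers for weaker inhibition;
compound 2, `CCCOC(=O)C1=C(C)NC(C)=C(C(=O)OC)C1c1csc(-c2ccc(Cl)cc2)n1`, gives 5920 nM in this assay;
compound 3, `CCCOC(=O)C1=C(C)NC(C)=C(C(=O)OCC)C1c1csc(-c2ccc(Cl)cc2)n1`, gives 4090 nM in this assay.

Compound 3 has the smallest of the three numbers, but a 1.2-fold lower number from compound 1 to compound 3 (0.07 log units; within the scatter) and a 1.4-fold lower number from compound 2 to compound 3 (0.16 log units; within the scatter) are both within the scatter, as is a 1.2-fold higher number from compound 1 to compound 2 (0.09 log units; within the scatter), so the three compounds are not separated on this read-out. All three share one core and differ only in the chain of one ester group.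

Compound 4, `CCOC(=O)C1=C(C)NC(C)=C(C(=O)OCC(C)C)C1c1csc(-c2ccc(Cl)cc2)n1`, has not been measured. It differs from compound 3 by methyl in place of hydrogen on a saturated chain carbon bound to two saturated chain carbons. The three measured steps all change the length of an ester chain, and each stays within the scatter; none of them adds a branch, so the closest guide is simply that shortening or lengthening these chains has left the number essentially unchanged. The branching in compound 4 is therefore expected to give no step beyond the scatter in this assay, in either direction.

The step from compound 3 to compound 4 is estimated as a 1.1-fold higher number from compound 3 to compound 4 (0.04 log units; within the scatter). For compound 4 the estimated value is 4500 nM, with a range from 2000 nM to 10000 nM.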

Compound 4, half-maximal inhibitory concentration: 15400 nM
Beside the measured number, compound 4's estimate is 3.4-fold (0.53 log units) below it; the measured number lies above the stated range.
By their numbers in this assay, from the lowest: compounds 3, 1 and 2 (each within the scatter of the next); then compound 4.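

In this assay, within the data shown here, the change from propyl to isobutyl in an ester chain gives the only step in this set that lies beyond the scatter (a 3.8-fold higher number from compound 3 to compound 4 (0.58 log units; beyond the scatter)). The steps that changed only the length of an ester chain, such as (a 1.2-fold higher number from compound 1 to compound 2 (0.09 log units; within the scatter)) and (a 1.4-fold lower number from compound 2 to compound 3 (0.16 log units; within the scatter)), stayed within the scatter, so this methyl on a saturated chain carbon bound to two saturated chain carbons separates two compounds in a way those changes of length did not. No available evidence bears on why this step is so much larger than the others.

A straight butyl chain at this place would show whether the higher number goes with the branch itself or with the added carbon, and a tert-butyl or cyclopropylmethyl group would show how far the result extends to other branched shapes. From the compounds shown here alone, it also remains open whether the same methyl on the other ester chain would give a step of similar size, and whether an ester chain ending in an amine would behave like either the straight or the branched chains.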